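This account rests on a few compounds, and the source may have more. Where it says the series, first, only, none or still open, it means among the compounds named here.

Of the compounds shown here, three have been measured in a functional assay on CCRF-CEM cells (Homo sapiens) for inhibition, read by cell counting, with a stated time of 3 days; a lower number here means a stronger inhibitor, a higher number a weaker inhibitor. Compound 1 `C=C(Br)C(=O)Nc1cccc(-c2cn3nc(-c4cccc(OC)c4)sc3n2)c1` gives 1200 nM. Compound 2 `Nc1cccc(-c2cn3c(-c4ccccc4)csc3n2)c1` gives 29000 nM, and compound 3 `COc1ccc(-c2csc3nc(-c4cccc(N)c4)cn23)cc1` gives 6100 nM. The shared part of compound 2 and compound 3 differs from the core of compound 1; that difference between the two cores is not broken down here. Compound 3 differs from compound 2 by methoxy in place of hydrogen on an aromatic carbon, and this step brought a 4.8-fold lower number from compound 2 to compound 3 (0.68 log units; beyond the scatter).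

Compound 4 `C=C(Br)C(=O)Nc1cccc(-c2cn3nc(-c4ccc(OC)c(OC)c4)sc3n2)c1` has not yet been measured. It differs from compound 1 by methoxy in place of hydrogen on an aromatic carbon. Within the data shown here, the change is the same kind of change as the one from compound 2 to compound 3, but not the same: in compound 4 the new group sits ortho to a methoxy group (2 heavy atoms), while in compound 3 it sits only para to a large group, and the cores differ as well.

Compound 4 is expected to give a step of a 2.0-fold lower number from compound 1 to compound 4 (0.30 log units; within the scatter), estimated as smaller than the earlier step, because a 4.8-fold lower number from compound 2 to compound 3 (0.68 log units; beyond the scatter) was made on a different core and at a different place. The estimate for compound 4 is 600 nM, with a range expected between 200 nM and 1800 nM.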

Compound 4, half-maximal inhibitory concentration: 380 nM
Compound 4: middle estimate off by 1.6-fold (0.20 log units), on the high side; measured number inside the range.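

Turning 3-methoxyphenyl into 3,4-dimethoxyphenyl brought a 3.2-fold lower number from compound 1 to compound 4 (0.50 log units; beyond the scatter) in this assay. The same kind of change, methoxy in place of hydrogen on an aromatic carbon, lowered the number on both cores, and the two steps cannot be told apart in size: the same change on two cores in this assay, a 4.8-fold lower number (0.68 log units; beyond the scatter) from compound 2 to compound 3 and a 3.2-fold lower number (0.50 log units; beyond the scatter) from compound 1 to compound 4, 1.5-fold (0.18 log units) apart, within the scatter of two such steps. This shows that, for these two pairs, the gain carried over from one core to the other in direction and roughly in size, but two pairs do not make a rule for the series, the new group is ortho to a methoxy group only in compound 4, and nothing here explains why the number falls.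

Going by these compounds, whether an ethoxy group, a hydroxy group or a fluorine atom in the same place would also lower the number remains open. So does whether the methoxy step would hold on the core of compound 1 with a free amine, as in compound 2 and compound 3, in place of the bromine-bearing amide.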